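The compounds below may be only part of what the source reports. "The series", "measured", "known", "first", "only" and "open" are said of these compounds alone.

In a functional assay on HepG2 cells (Homo sapiens) for cytotoxicity, with a stated time of 72 h (a higher number here means that more compound is needed for the effect, a lower number that less compound is needed), compound 1 `C=C[C@](C)(CCCC(C)C)CCc1ccc(O)cc1` gives > 52000 nM as a limit of the assay and not a number. In this assay compound 2 `CC(C)=CCC[C@@](C)(/C=C/c1ccccc1)/C=C/c1ccc(O)cc1` gives > 52000 nM as a limit of the assay and not a number, and the expectation for its analogue rests on that limit. Compound 2 thus stands at the limit of > 52000 nM in this assay, at which 2 of the 2 values shown sit, and has no number of its own. Compound 3 `CC(C)=CCC[C@](C)(/C=C/c1ccc(O)cc1)/C=C/c1cccc(F)c1` carries fluoro in place of hydrogen on an aromatic carbon, meta to a large group, with fluoro in place of hydrogen on an aromatic carbon as the counted difference from compound 2. For the measured compounds named here, no measured step shows what this change does. No shift beyond the scatter is expected in this assay and neither direction is favoured. The estimate is a step that the limit leaves unreadable from compound 2 to compound 3 and no more than that. Compound 3 is expected at 55000 nM with an estimated range from 25000 nM to 100000 nM, and a limit of the assay is again likely.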

Compound 3, half-maximal effective concentration: > 52000 nM
Compound 3: only a limit was reported; the forecaster's own chance of this, stated with the estimate: 80%; the middle value does not contradict the limit.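

Compound 2 and compound 3 both stand at a limit of the assay in this assay, so no step can be read between them. The compounds shown leave open how much of any of them this effect requires, and whether fluoro in place of hydrogen changes it.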